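Carboxy for methyl on the benzyl group of a quinazoline amide

The compounds below may be only part of what the source reports. "The series", "measured", "known", "first", "only" and "open" are said of these compounds alone.

Measured so far:
compound 1, `CCN(Cc1ccccc1)C(=O)c1nc(-c2ccc(Cl)cc2)c2ccccc2n1`, 0.762 nM
compound 2, `CCN(Cc1ccc(C)cc1)C(=O)c1nc(-c2ccccc2)c2ccccc2n1`, 2.57 nM

Of the compounds shown here, two share a core and have been tested in an assay on cell membranes from kidney for displacement of a labelled ligand from Translocator protein (Rattus norvegicus); a higher number here means a weaker inhibitor, a lower number a stronger inhibitor. Compound 1 gives 0.762 nM. Compound 2 gives 2.57 nM, the higher of the two numbers, and the gap between compound 1 and compound 2 lies beyond the usual scatter. The two compounds differ in more than one place, so the gap cannot be tied to a single change.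

Compound 3, `CCN(Cc1ccc(C(=O)O)cc1)C(=O)c1nc(-c2ccccc2)c2ccccc2n1`, has not yet been measured. It differs from compound 2 in one place: carboxy in place of methyl on an aromatic carbon. Going by the values given here, no measured pair shows this change, so the expectation rests only on compounds 1 and 2 and on the nature of the change. A carboxy group entering in place of methyl is expected to raise the number in this assay, a step from compound 2 to compound 3 of about a 16-fold higher number from compound 2 to compound 3 (1.19 log units; beyond the scatter). Compound 3 is therefore estimated at 40 nM, with a range from 5 nM to 400 nM.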

Compound 3, inhibition constant: 719 nM
Compound 3: middle estimate off by 18-fold (1.25 log units), on the low side; measured number outside the range, above it.
By their numbers in this assay, from the lowest: compound 1; then compound 2; then compound 3.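

In this assay, going by these compounds alone, the change from 4-methylbenzyl to 4-carboxybenzyl gives a 280-fold higher number from compound 2 to compound 3 (2.45 log units; beyond the scatter), the first step here that can be tied to a single place. It shows that this position on the benzyl ring is far from indifferent to what it carries, and that carboxy in place of methyl is a large penalty there. No measurement at hand explains the size of this step.

As far as these compounds go, what remains open is whether this penalty belongs to the carboxylic acid itself or would also appear with its methyl ester, its primary amide, a hydroxymethyl group or an amine at the same place. Also open, from the compounds shown here alone, is whether a carboxy on the benzyl group of compound 1 would bring a step of similar size.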